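The source may report more compounds than this note shows. Statements on the series, on what has been measured and on what is new or still open speak of the compounds shown alone.

In a functional assay on K562 cells (Homo sapiens) for inhibition, read by MTT assay, with a stated time of 72 h (a lower number here means a stronger inhibitor, a higher number a weaker inhibitor), compound 2 `COc1cc(/C=C\c2cccc3c2oc(=O)n3C)cc(OC)c1OC` gives 710 nM. Compound 3 `COc1cc(/C=C\c2cccc3c2oc(=O)n3C)cc(OC)c1` gives 950 nM, within the scatter of compound 2. Compound 1 `COc1ccc(/C=C\c2cccc3c2oc(=O)n3C)cc1`, which carries fewer methoxy groups, gives only a limit, > 50000 nM.

Compound 4 `COc1ccc(/C=C\c2cccc3c2oc(=O)n3C)cc1OC` follows from compound 2 by hydrogen in place of methoxy on an aromatic carbon, ortho to a methoxy group and meta to a methoxy group. Going by the values given here, the one measured step of this kind, a 1.3-fold higher number from compound 2 to compound 3 (0.13 log units; within the scatter), stays within the scatter. The limit for compound 1 still warns that such losses need not stay small. A modest move toward a higher number in this assay is therefore expected, with an estimated step of a 2.5-fold higher number from compound 2 to compound 4 (0.40 log units; beyond the scatter). Compound 4 is expected at 1800 nM, with an estimated range of 500 nM to 10000 nM.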

Compound 4, half-maximal inhibitory concentration: > 50000 nM
Compound 4 gave a limit, no number; the forecaster's own chance of this, stated with the estimate: 10%; at least 27-fold (1.44 log units) between middle value and limit.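

The methoxy ortho to a methoxy group and meta to a methoxy group carries far more weight in this assay than the first replacement suggested: hydrogen in its place gives an at least 70-fold higher number from compound 2 to compound 4 (1.84 log units; beyond the scatter), whereas the same replacement at a different carbon gives a 1.3-fold higher number from compound 2 to compound 3 (0.13 log units; within the scatter). The value of compound 4, > 50000 nM, is a limit and not a number. The step between compound 1 and compound 4 cannot be read, and the limit is shared: the limit of > 50000 nM in this assay, at which 2 of the 4 values shown sit.

Open, from the compounds shown here alone, is whether a hydroxyl, an amine or a chlorine atom in place of this methoxy would hold the value of compound 2, 710 nM.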